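A few compounds are considered here, and "the series" means these few. Any claim that something is new, unique, unknown or untested is made for them only; others in the source may bear on it.

Measured in a functional assay on PC-3 cells (Homo sapiens) for inhibition, read by MTT assay, with a stated time of 48 h, tested at 10 uM; a lower number here means less inhibition of growth, a higher number more inhibition of growth at the concentration tested:
- compound 1 `Cc1oc2c([C@H]3CCN(C)C[C@H]3O)c(O)cc(O)c2c(=O)c1C(O)c1ccc(Cl)cc1`: 41%
- compound 2 `Cc1oc2c([C@H]3CCN(C)C[C@H]3O)c(O)cc(O)c2c(=O)c1C(O)c1csc([N+](=O)[O-])c1`: 0%

Within the data shown here, compound 2, at 0%, is the lower of the two compounds measured so far in this assay, well beyond the scatter from compound 1.

The next compound is compound 3 `Cc1oc2c([C@H]3CCN(C)C[C@H]3O)c(O)cc(O)c2c(=O)c1C(O)c1ccc(F)cc1`. The change is 4-fluorophenyl in place of 5-nitrothiophen-3-yl on a saturated chain carbon bound to an aromatic carbon and an oxygen on a saturated carbon.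

Among the measured compounds shown here, only one measured step bears on this. At the same place, 5-nitrothiophen-3-yl in place of 4-chlorophenyl gave a number 41 percentage points lower from compound 1 to compound 2 (beyond the scatter), a large step. The new change leaves the same group and brings back a phenyl ring carrying a halogen, so a large step in the opposite direction is expected. For the measured compounds named here, no fluorine compound has been measured, so the value of compound 1, 41%, is only a guide, and the estimate is set slightly under it with a wide range.

The expected change is a number 35 percentage points higher from compound 2 to compound 3 (beyond the scatter).

For compound 3 the estimated value is 35%, with an expected range of 15% to 55%.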

Compound 3, percent growth inhibition at one concentration: 0%
For compound 3 the middle estimate is 35 percentage points above the measured one; measured number outside the range, below it.
By their numbers in this assay, from the lowest: compounds 2 and 3 (each within the scatter of the next); then compound 1.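

In this assay, fluoro in place of chloro on an aromatic carbon gives a number 41 percentage points lower from compound 1 to compound 3 (beyond the scatter), so a phenyl ring carrying a halogen at this place is not by itself enough for growth inhibition, and the identity of the halogen matters in this pair. The exchange of 5-nitrothiophen-3-yl for 4-fluorophenyl gives no change at the digits printed from compound 2 to compound 3 (within the scatter), so two quite different groups on the saturated chain carbon read alike at the concentration tested, and of the three compounds only compound 1, with its 4-chlorophenyl group and 41%, stands apart. Nothing at hand gives a reason for the gap between the chloro and fluoro compounds.

Still open, from the compounds shown here alone, is whether the activity of compound 1 is particular to chloro or extends to other groups on the same aromatic carbon, such as bromo, methyl, methoxy or trifluoromethyl, and how a plain phenyl ring would read against these. A single concentration also leaves open whether compound 2 and compound 3 would separate at other concentrations.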